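Trimming the acyl group in a sulfonylcarbamate series

A few compounds are considered here, and "the series" means these few. Any claim that something is new, unique, unknown or untested is made for them only; others in the source may bear on it.

Compound 1, `CCCC(=O)N(CCC(=O)c1c(CC)nc(CCC)n1Cc1ccc(-c2ccccc2S(=O)(=O)NC(=O)OCCC(C)C)cc1F)c1ccccc1`, gives 0.15 nM in an assay on isolated protein for inhibition of Type-2 angiotensin II receptor (Rattus norvegicus); a higher number here means a weaker inhibitor, a lower number a stronger inhibitor. Compound 2, `CCCc1nc(CC)c(C(=O)CCN(C(=O)c2ccncc2)c2cccnc2)n1Cc1ccc(-c2ccccc2S(=O)(=O)NC(=O)OCCC(C)C)cc1F`, gives 1 nM. Compound 3, `CCCc1nc(CC)c(C(=O)CCN(C(=O)C(C)C)c2cccnc2)n1Cc1ccc(-c2ccccc2S(=O)(=O)NC(=O)OCCC(C)C)cc1F`, gives 1 nM.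

Compound 3 stands level with compound 2, the two sharing the highest number of the three, and it is separated from compound 1 by the step of a 6.7-fold higher number from compound 1 to compound 3 (0.82 log units; beyond the scatter). Compound 4, `CCCc1nc(CC)c(C(=O)CCN(C(=O)CC)c2cccnc2)n1Cc1ccc(-c2ccccc2S(=O)(=O)NC(=O)OCCC(C)C)cc1F`, differs from compound 3 by hydrogen in place of methyl on a saturated chain carbon bound to a carbonyl carbon and a saturated chain carbon. The step that bears most on this is no change at the digits printed from compound 2 to compound 3 (within the scatter), which replaced the whole acyl group with no effect, whereas a 6.7-fold higher number from compound 1 to compound 3 (0.82 log units; beyond the scatter) altered both the amide aryl and the acyl at once. Removing a single methyl is therefore expected to do little. Compound 4 is estimated at 1 nM (range 0.4 nM to 3 nM). This expectation amounts to no change at the digits printed from compound 3 to compound 4 (within the scatter).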

Compound 4, half-maximal inhibitory concentration: 0.49 nM
Beside the measured number, compound 4's estimate is 2.0-fold (0.31 log units) above it; the range from low to high includes it.
By their numbers in this assay, from the lowest: compound 1; then compound 4; then compounds 2 and 3 (each within the scatter of the next).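

On the pyridin-3-yl amide, removing one methyl, isopropyl to ethyl, gives a 2.0-fold lower number from compound 3 to compound 4 (0.31 log units; beyond the scatter) and so moves the number, whereas exchanging isopropyl for pyridin-4-yl had not. Ethyl in place of pyridin-4-yl gives a 2.0-fold lower number from compound 2 to compound 4 (0.31 log units; beyond the scatter) and shows that this acyl position can respond to its substituent. The remaining gap is a 3.3-fold higher number from compound 1 to compound 4 (0.51 log units; beyond the scatter) and spans both acyl and amine aryl changes, and no evidence is available to explain these shifts.

As far as these compounds go, whether shortening further to acetyl continues the change remains open. So does how much of that gap belongs to phenyl rather than pyridin-3-yl.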